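Methoxy on the Ring: What Compound 4 Might Show

A few compounds are considered here, and "the series" means these few. Any claim that something is new, unique, unknown or untested is made for them only; others in the source may bear on it.

Compound 1 `CC(C)(C)OC(=O)/C=C1/C(=O)Nc2ccccc21` is the parent of a small set of compounds that share one core. Among the measured compounds shown here, in a functional assay on HepG2 cells (Homo sapiens) for inhibition, read by CCK-8 assay, with a stated time of 72 h, tested at 20 uM (a higher number here means more inhibition of growth at the concentration tested, a lower number less inhibition of growth), compound 1 gives 86.1%, the lowest of the three numbers measured so far, though its gaps to both neighbours are within the scatter. Compound 2 `CC(C)c1ccc2c(c1)/C(=C\C(=O)OC(C)(C)C)C(=O)N2`, which carries isopropyl on an aromatic carbon, gives 90.5% in this assay, and compound 3 `CCCCc1ccc2c(c1)/C(=C\C(=O)OC(C)(C)C)C(=O)N2`, with butyl on an aromatic carbon, gives 90.3%. The step of a number 4.4 percentage points higher from compound 1 to compound 2 (within the scatter) and the step of a number 4.2 percentage points higher from compound 1 to compound 3 (within the scatter) both stay within the scatter, as does a number 0.2 percentage points lower from compound 2 to compound 3 (within the scatter); adding a group to the ring has so far left the read-out essentially unchanged.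

Compound 4 `COc1cccc2c1NC(=O)/C2=C/C(=O)OC(C)(C)C` differs from compound 1 by methoxy in place of hydrogen on an aromatic carbon. For the measured compounds named here, no measured step adds methoxy, so the bearing of the earlier steps is indirect. Because the steps of a number 4.4 percentage points higher from compound 1 to compound 2 (within the scatter) and a number 4.2 percentage points higher from compound 1 to compound 3 (within the scatter) stayed within the scatter, no change beyond the scatter is expected in this assay for a further small group on the ring. Compound 4 is therefore expected to give about 85%, with a range from 74% to 94%. That estimate amounts to a step of a number 1.1 percentage points lower from compound 1 to compound 4 (within the scatter).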

Compound 4, percent growth inhibition at one concentration: 87.3%
Compound 4: middle estimate off by 2.3 percentage points, on the low side; the measured number falls inside the stated range.
By their numbers in this assay, from the lowest: compounds 1, 4, 3 and 2 (each within the scatter of the next).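

The step from hydrogen to methoxy in this assay is a number 1.2 percentage points higher from compound 1 to compound 4 (within the scatter), so this assay does not separate the two compounds. Methoxy brings oxygen and 1 hydrogen-bond acceptor onto an aromatic carbon that is ortho to a fused ring and meta to a fused ring, and this is the first group in the set that contains oxygen, yet the step stays within the scatter, as the steps to isopropyl and butyl do. No measurement shown here explains why the number stays within the scatter of compound 1.

On these data alone, it remains open whether an amine or a carboxylic acid on this same aromatic carbon would give a step beyond the scatter. A longer chain ending in an amine poses the same question.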